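This account rests on a few compounds, and the source may have more. Where it says the series, first, only, none or still open, it means among the compounds named here.

Series notes. Compound 1 `COc1ccc(Cn2c(-c3ccccc3O)c(Br)c3ccccc3c2=O)cc1` in a functional assay on HeLa cells (Homo sapiens) for cytotoxicity, read by sulforhodamine B assay (a lower number here means a stronger inhibitor, a higher number a weaker inhibitor), gives 36800 nM, the highest of the two numbers in hand. For the measured compounds named here, the only measured neighbour is compound 2 `COc1ccc(Cn2c(-c3ccccc3O)c(Br)c3cc(C)ccc3c2=O)cc1`, which in this assay gives 20400 nM; the step of a 1.8-fold lower number from compound 1 to compound 2 (0.26 log units; within the scatter), methyl in place of hydrogen on an aromatic carbon, is within the scatter, so the two are read as equal.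

The next compound, compound 3 `C=COc1ccccc1-c1c(Br)c2ccccc2c(=O)n1Cc1ccc(OC)cc1`, differs from compound 1 by vinyl in place of hydrogen on an oxygen on an aromatic ring, that is hydroxy to vinyloxy, 2-hydroxyphenyl to 2-(vinyloxy)phenyl. Going by the values given here, no measured step touches this oxygen; the one step on record, from compound 1 to compound 2, sits on an aromatic carbon of the core and lies within the scatter, so it gives no direction for a change at the hydroxy group. With nothing in the series speaking for a gain or a loss, the expected step of a 1.1-fold higher number from compound 1 to compound 3 (0.04 log units; within the scatter) is none beyond the scatter, with a wide range to cover either outcome. Compound 3 in this assay is therefore estimated at 40000 nM, between 12000 nM and 130000 nM.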

Compound 3, half-maximal inhibitory concentration: 36500 nM
Beside the measured number, compound 3's estimate is 1.1-fold (0.04 log units) above it, within the range that was stated.
By their numbers in this assay, from the lowest: compounds 2, 3 and 1 (each within the scatter of the next).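

For the compounds shown here, this is the first measured change at the oxygen on the aromatic ring: going from hydroxy to vinyloxy gives a 1.0-fold lower number from compound 1 to compound 3 (0.00 log units; within the scatter) in this assay. The 2-hydroxyphenyl group of compound 1 can therefore give way to the 2-(vinyloxy)phenyl group of compound 3 with no readable difference in this assay, so for this pair the hydrogen on that oxygen is not needed to hold the number. Nothing at hand bears on why the two compounds read alike.

The compounds shown leave open whether this tolerance extends to other groups on the same oxygen, such as a methyl, a longer chain like butyl, or a chain ending in an amine or a carboxylic acid, any of which might give a step beyond the scatter. It also remains open whether vinyl on this oxygen reads the same on the core of compound 2, which carries the methyl on an aromatic carbon, since only single changes from compound 1 are shown here.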